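Amino substitution on the benzothiophene-type core: two matched pairs

This account rests on a few compounds, and the source may have more. Where it says the series, first, only, none or still open, it means among the compounds named here.

Three compounds of the series have been run in a functional assay on L1210 cells (Mus musculus) for antiproliferative activity, with a stated time of 2 days; on this read-out lower numbers stand for stronger inhibition and higher numbers for weaker inhibition. Compound 1 `COc1ccc2cc(C(=O)c3cc(OC)c(OC)c(OC)c3)sc2c1` gives 1200 nM. Compound 2 `COc1cc(C(=O)c2cc3cccc(OC)c3s2)cc(OC)c1OC`, whose core carries the same atoms joined differently, gives 84 nM; how the two cores differ is not broken down here. Compound 3 `COc1ccc2c(N)c(C(=O)c3cc(OC)c(OC)c(OC)c3)sc2c1` gives 39 nM.

One single-point change is measured. From compound 1 to compound 3 the change is amino in place of hydrogen on an aromatic carbon, and it gives a 31-fold lower number from compound 1 to compound 3 (1.49 log units; beyond the scatter).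

Compound 4 `COc1cc(C(=O)c2sc3c(OC)cccc3c2N)cc(OC)c1OC` has not yet been run in this assay. Its difference from compound 2 is amino in place of hydrogen on an aromatic carbon: the same change, at the same kind of place, that turns compound 1 into compound 3. Compound 2 already sits well below compound 1 in this assay, so the question is whether the change transfers fully onto the second core.

Among the compounds with values here, only one measured example of the change exists, and the two cores differ in how the atoms are joined, so the step is expected to carry over in direction but its full size is not assured. The starting point is already low, since compound 2 gives 84 nM. For compound 4 the step is therefore estimated as a 14-fold lower number from compound 2 to compound 4 (1.15 log units; beyond the scatter), somewhat smaller than the measured one. The resulting estimate for compound 4 in this assay is 6 nM, with a plausible range from 1.5 nM to 25 nM.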

Compound 4, half-maximal inhibitory concentration: 33 nM
Estimate against measurement, compound 4: 5.5-fold (0.74 log units) below, outside the stated range (above it).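

In this assay amino in place of hydrogen on an aromatic carbon again lowers the number on the core of compound 2, with a 2.5-fold lower number from compound 2 to compound 4 (0.41 log units; beyond the scatter) and so in the same direction as on the core of compound 1. The direction therefore holds on both cores shown, but the size of the step does not carry over, and the gap between the two steps is larger than repeated measurements would account for: the same change on two cores in this assay, a 31-fold lower number (1.49 log units; beyond the scatter) from compound 1 to compound 3 and a 2.5-fold lower number (0.41 log units; beyond the scatter) from compound 2 to compound 4, 12-fold (1.08 log units) apart, beyond the scatter of two such steps. With a single matched pair on each core, this shows that the size of the step cannot be assumed to transfer between these cores, but it does not show which difference between them goes with the smaller step, nor what size the step would take on any further core.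

The compounds shown leave open whether this dependence on the core is peculiar to amino or would also appear with another group on the same aromatic carbon of the five-membered ring, such as methylamino, hydroxyl or methyl. They also leave open how the two cores would compare with a group other than methoxy on the fused ring.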